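The source may report more compounds than this note shows. Statements on the series, on what has been measured and on what is new or still open speak of the compounds shown alone.

Compound 2 `CC(C)(O)C(=O)Nc1cc(Oc2ccc(Nc3nccc4[nH]cc(-c5ccc(F)cc5)c(=O)c34)cc2F)ccn1` stands second highest of the three numbers in a functional assay on MKN-45 cells (Homo sapiens) for antiproliferative activity, read by MTT assay, with a stated time of 72 h, tested at 10 uM (a lower number here means less inhibition, a higher number more inhibition at the concentration tested (going by the name of the read-out)), where compound 2 gives 57.8%. Its nearest neighbour is compound 1 `CCCC(=O)Nc1cc(Oc2ccc(Nc3nccc4[nH]cc(-c5ccc(F)cc5)c(=O)c34)cc2F)ccn1`, which in this assay gives 64.6%; the furthest is compound 3 `CCn1cc(-c2ccc(F)cc2)c(=O)c2c(Nc3ccc(Oc4ccnc(NC(=O)C5CC5)c4)c(F)c3)nccc21`, which in this assay gives 31.9%. The measured step of a number 6.8 percentage points lower from compound 1 to compound 2 (within the scatter) is the only one that bears on the change to compound 4 `O=C(Nc1cc(Oc2ccc(Nc3nccc4[nH]cc(-c5ccc(F)cc5)c(=O)c34)cc2F)ccn1)C1CCC1`, namely (cyclobutyl in place of 1-hydroxy-1-methylethyl on a carbonyl carbon). Compound 3 differs from compound 2 in more than one place, so its value shows only what its own structure yields. Since that one relevant step was within the scatter, the cyclobutyl is expected to leave this assay little changed, with an expected step of a number 4.2 percentage points higher from compound 2 to compound 4 (within the scatter). Compound 4 is therefore estimated at 62%, between 45% and 76%.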

Compound 4, a percentage reported as inhibition, at one concentration (the size of the read-out at that concentration, not a potency): 52.8%
For compound 4 the middle estimate is 9.2 percentage points above the measured one; the range from low to high includes it.
By their numbers in this assay, from the lowest: compound 3; then compounds 4, 2 and 1 (each within the scatter of the next, the first and the last beyond it).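

In this assay, cyclobutyl in place of 1-hydroxy-1-methylethyl on the carbonyl carbon gives a number 5 percentage points lower from compound 2 to compound 4 (within the scatter), so removing that group's hydrogen-bond donor and acceptor has no resolved effect here. Cyclobutyl in place of propyl gives a number 11.8 percentage points lower from compound 1 to compound 4 (beyond the scatter), the first modest step at this position, although compound 2 lies within the scatter of both compound 1 and compound 4. Nothing available explains either step. As far as these compounds go, it remains open how an amine, a carboxylic acid or a longer chain on this carbonyl carbon would compare. From the compounds shown here alone, whether a cyclopentyl would follow cyclobutyl is equally open.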